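Moving a methyl on the aniline of compound 1

The source may hold more compounds than are shown below. What is called first, only, known or untested is meant among the compounds shown, and "the series" means these compounds.

Compound 1 `Cc1ccc(Nc2ncc(C(F)(F)F)c(N3Cc4cccc(N(C)S(C)(=O)=O)c4C3)n2)cc1C`: > 30000 nM in a functional assay on A549 cells (Homo sapiens) for antiproliferative activity, read by spectrophotometry, with a stated time of 2 days; on this read-out higher numbers stand for weaker inhibition of growth and lower numbers for stronger inhibition of growth
Compound 2 `COc1cc(Nc2ncc(C(F)(F)F)c(N3Cc4cccc(N(C)S(C)(=O)=O)c4C3)n2)c(OC)cc1Cl`: 7300 nM
Compound 3 `COc1cc(Nc2ncc(C(F)(F)F)c(N3Cc4cccc(N(C)S(C)(=O)=O)c4C3)n2)cc(OC)c1`: 24800 nM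

In this assay compound 1 gives only a limit, > 30000 nM, and no number, so it stands at the weak end of the three (the limit of > 30000 nM in this assay, at which 1 of the 3 values shown sits). Compound 2 reaches 7300 nM, a step of an at least 4.1-fold lower number from compound 1 to compound 2 (0.61 log units; beyond the scatter), while compound 3, at 24800 nM, shows an at least 1.2-fold lower number from compound 1 to compound 3 (0.08 log units; that floor lies within the scatter); between them lies a 3.4-fold higher number from compound 2 to compound 3 (0.53 log units; beyond the scatter).

Compound 4 `Cc1ccc(Nc2ncc(C(F)(F)F)c(N3Cc4cccc(N(C)S(C)(=O)=O)c4C3)n2)c(C)c1` differs from compound 1 by 2,4-dimethylphenyl in place of 3,4-dimethylphenyl on a nitrogen on an aromatic ring. Among the measured compounds shown here, none of the measured steps moves a methyl within the same ring; each swaps the whole aryl group, so they only frame what a small change here might do. The one gain seen, from compound 1 to compound 2, came with a different set of groups altogether, and the gain from compound 3 to compound 2 is modest. For compound 4 the expectation is therefore a step of a number no higher from compound 1 to compound 4 (the limit leaves the size open), close to where compound 1 stands. Compound 4 is estimated at 30000 nM, in a range from 8000 nM to 100000 nM, with a fair chance that this assay again reports only a limit.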

Compound 4, concentration for 50% growth inhibition: 20700 nM
Beside the measured number, compound 4's estimate is 1.4-fold (0.16 log units) above it; measured number inside the range.
By their numbers in this assay, from the lowest: compound 2; then compounds 4 and 3 (each within the scatter of the next). At a limit, above all of these: compound 1.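

Moving one methyl, from the 3,4-dimethylphenyl of compound 1 to the 2,4-dimethylphenyl of compound 4, keeps the same atoms and changes only how they are joined, and in this assay this arrangement gives a measurable number. On these data alone, with a limit for compound 1, the change reads only as an at least 1.4-fold lower number from compound 1 to compound 4 (0.16 log units; that floor lies within the scatter), so its true size stays unknown: the limit of > 30000 nM in this assay, at which 1 of the 4 values shown sits. Against the other aryl groups, the 2,4-dimethylphenyl shows a 1.2-fold lower number from compound 3 to compound 4 (0.08 log units; within the scatter), which is no real difference, and a 2.8-fold higher number from compound 2 to compound 4 (0.45 log units; beyond the scatter), so the 4-chloro-2,5-dimethoxyphenyl group keeps its lead.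

What these compounds leave open is how far compound 1 truly lies from compound 4. They also leave open whether a different group on this ring, such as an ethyl or a basic amine like morpholine, would bring growth inhibition closer to that of compound 2.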